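The source may report more compounds than this note shows. Statements on the series, on what has been measured and on what is new or still open speak of the compounds shown alone.

The measured compounds and their values:

Compound 1, `COc1ccc(CN(C(C)=O)c2cc(OC)c(OC)c(OC)c2)cc1O`: in a functional assay on KYSE-450 cells (Homo sapiens) for inhibition, read by MTT assay, with a stated time of 48 h (on this read-out lower numbers stand for stronger inhibition and higher numbers for weaker inhibition), compound 1 gives 160 nM.
Compound 2, `C/C=C/C(=O)N(Cc1ccc(OC)c(N)c1)c1cc(OC)c(OC)c(OC)c1`: in this assay compound 2 gives 310 nM.
Compound 3, `COc1cc(NCc2ccc(Br)cc2)cc(OC)c1OC`: in this assay compound 3 shows only > 80000 nM, which is a limit of the assay and not a number.

Compound 1 carries the lowest of the two numbers recorded, and the nearest is compound 2, whose number is higher by a gap that lies within the scatter of repeated measurements; no order between compound 1 and compound 2 can therefore be claimed. Of the three values, one sits at the limit (the limit of > 80000 nM in this assay, at which 1 of the 3 values shown sits), so compound 3 adds no number to compare.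

The account now follows the step from compound 1 to compound 4, `COc1ccc(CN(C(=O)CBr)c2cc(OC)c(OC)c(OC)c2)cc1O`, which has not yet been measured. The change between them is bromo in place of hydrogen on a saturated chain carbon bound to a carbonyl carbon. Going by the values given here, no step between measured compounds shares this change, so nothing yet measured fixes its size. In this assay the step is expected to be small, likely within the scatter, with a modest lean toward a lower number rather than a higher one. For compound 4 the estimate is 100 nM, with a range from 30 nM to 400 nM, meaning an expected step of a 1.6-fold lower number from compound 1 to compound 4 (0.20 log units; within the scatter).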

Compound 4, half-maximal inhibitory concentration: 120 nM
For compound 4 the middle estimate is 1.2-fold (0.08 log units) below the measured one; low and high end bracket the measured number.
By their numbers in this assay, from the lowest: compounds 4, 1 and 2 (each within the scatter of the next, the first and the last beyond it). At a limit, above all of these: compound 3.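

In this assay, the first step seen at this position, methyl to bromomethyl, gives a 1.3-fold lower number from compound 1 to compound 4 (0.12 log units; within the scatter), so no change in either direction can be claimed. The earlier compounds shown here left this place untested; now a single bromine atom on the saturated chain carbon bound to a carbonyl carbon is seen to leave the number of compound 4 at 120 nM, within the scatter of compound 1. Nothing measured here gives a cause for this step or bears on one.

On these data alone, whether a chloro group, an amine or a longer chain at this carbon would also stay within the scatter of compound 1 remains open. Also open, as far as these compounds go, is whether replacing the acetyl with a carboxylic acid would move the number beyond the scatter.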